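Phenoxy to hydroxy in a series without measurable cytotoxicity

The compounds below may be only part of what the source reports. "The series", "measured", "known", "first", "only" and "open" are said of these compounds alone.

Compound 3 `CCOC(=O)CCCCCOc1cccc(CN(C(=O)c2ccc(-c3cccc(Oc4ccccc4)c3)cc2)C(C)C)c1` carries a phenoxy substituent on its outer aromatic ring. In an ADME assay on Raji cells (Homo sapiens) for cytotoxicity, read by CellTiter-Glo and resazurin assay, with a stated time of 72 h (on this read-out lower numbers stand for an effect already at smaller amounts and higher numbers for an effect only at larger amounts of compound), compound 3 gives > 19600 nM, which is a limit of the assay rather than a number. Its two measured relatives also show only limits. Compound 1 `CCOC(=O)CCCCCOc1cccc(CN(C(=O)c2ccc(-c3cccc4ccccc34)cc2)C(C)C)c1` gives > 26000 nM in this assay, a limit. Compound 2 `CCOC(=O)CCCCCOc1cccc(CN(C(=O)c2ccc(-c3ccoc3)cc2)C(C)C)c1` gives > 26000 nM in this assay, again a limit. Going by the values given here, the only step between measured compounds, a step that the two limits leave unreadable from compound 1 to compound 2, is therefore not readable in size or direction. Compound 3 thus stands where every compound here stands: at the ceiling of the assay, as summarised by the limit of > 19600 nM in this assay, at which 1 of the 3 values shown sits, and (the limit of > 26000 nM in this assay, at which 2 of the 3 values shown sit).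

Compound 4 `CCOC(=O)CCCCCOc1cccc(CN(C(=O)c2ccc(-c3cccc(O)c3)cc2)C(C)C)c1` is the next variation: hydrogen in place of phenyl on an oxygen on an aromatic ring. Among the compounds with values here, no measured step bears on this change, since the single step available is unreadable. In this assay compound 4 is expected to stay at the limit, so the step that the limit leaves unreadable from compound 3 to compound 4 is expected to be nothing beyond the scatter. The estimate for compound 4 is 30000 nM, with a range from 10000 nM to 100000 nM, most probably reported as another limit.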

Compound 4, half-maximal effective concentration: > 26000 nM
Compound 4: a limit, no number (the forecaster's own chance of this, stated with the estimate: 85%); the middle value lies beyond the limit too.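

Compound 4, like compound 1, compound 2 and compound 3, shows only a limit in this assay, so the steps among these four compounds cannot be read in size or direction. The compounds shown leave open at what concentration, if any, one of them would give a measurable effect in this assay.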